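The source may report more compounds than this note shows. Statements on the series, on what has been measured and on what is new or still open speak of the compounds shown alone.

Of the compounds shown here, three built on one shared core have been tested in an assay on isolated protein for inhibition of DNA topoisomerase 1 (Homo sapiens), with a stated time of 30 min, tested at 20 uM; a higher number here means a stronger effect of the compound at the concentration tested, a lower number a weaker effect. Compound 1 `Cc1ccc2nc(-c3cccc(F)c3)[nH]c(=O)c2c1` gives 0.2% in this assay. Compound 2 `Cc1ccc2c(=O)[nH]c(-c3ccccc3F)nc2c1` gives 0% in this assay, and compound 3 `Cc1ccc2nc(-c3ccccc3OC(F)(F)F)[nH]c(=O)c2c1` gives 0% in this assay. The number for compound 1 is the highest of the three, but the gaps to compound 2 and to compound 3 both lie within the usual scatter of such measurements, so the three results read as one flat outcome near the floor of the assay.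

Compound 4 `COc1cccc(-c2nc3ccc(C)cc3c(=O)[nH]2)c1` has not yet been measured. It differs from compound 1 in a single place: methoxy in place of fluoro on an aromatic carbon. Among the compounds with values here, no two measured compounds differ from each other in only one place, so no step of this kind can be read from the numbers at hand. All three measured compounds sit at the floor of this assay, and compound 4 is expected to stay there as well. The step of a number 0.8 percentage points higher from compound 1 to compound 4 (within the scatter) is expected to be no larger than the scatter. Compound 4 is estimated at 1%, with a range from 0% to 10%.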

Compound 4, a percentage reported as inhibition, at one concentration (the size of the read-out at that concentration, not a potency): 0%
Compound 4: the middle estimate sits 1 percentage points above what was measured, within the range that was stated.
By their numbers in this assay, from the lowest: compounds 2, 3, 4 and 1 (each within the scatter of the next).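

In this assay, within the data shown here, the swap of fluoro for methoxy on an aromatic carbon, meta to a large group, gives a number 0.2 percentage points lower from compound 1 to compound 4 (within the scatter) and is the first single-place change that can be read directly. At this position, adding a hydrogen-bond acceptor and one more heavy atom therefore leaves the two compounds indistinguishable, and both stay at the floor of the assay. Nothing available explains this flat result.

Still open, as far as these compounds go, is whether a quite different group in this place, such as an amine, a carboxylic acid or a longer chain, would lift the number clear of the floor. A step read at the floor also cannot tell whether this position would matter on a compound with a clear effect in this assay at the concentration tested.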